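Compound 1 to compound 4: phenethyl for 4-bromophenyl

This account rests on a few compounds, and the source may have more. Where it says the series, first, only, none or still open, it means among the compounds named here.

Going by the values given here, in a functional assay on CCRF-CEM cells (Homo sapiens) for antiproliferative activity, read by MTT assay, with a stated time of 3 days (on this read-out lower numbers stand for stronger inhibition and higher numbers for weaker inhibition), compound 1 `O=C1c2ccccc2C(=O)N1C/C=C\Cn1cc(C#Cc2ccc(Br)cc2)c(=O)[nH]c1=O` gives 80000 nM, the highest of the three numbers so far. Compound 2 `CCCCCCC#Cc1cn(C/C=C/CN2C(=O)c3ccccc3C2=O)c(=O)[nH]c1=O` gives 28000 nM. Compound 3 `CCCCc1ccc(C#Cc2cn(C/C=C/CN3C(=O)c4ccccc4C3=O)c(=O)[nH]c2=O)cc1` gives 31000 nM. The numbers of compound 2 and compound 3 both lie beyond the scatter below that of compound 1.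

Compound 4 `O=C1c2ccccc2C(=O)N1C/C=C\Cn1cc(C#CCCc2ccccc2)c(=O)[nH]c1=O` is not yet measured. Its difference from compound 1 is phenethyl in place of 4-bromophenyl on a triple-bonded carbon.

Among the compounds with values here, no measured step starts from compound 1, and none tests this exact exchange. The closest evidence is a 1.1-fold higher number from compound 2 to compound 3 (0.04 log units; within the scatter), with 4-butylphenyl in place of hexyl on a triple-bonded carbon. That one step, within the scatter, gives no sign that a change at this place moves this assay much, so no shift beyond the scatter is expected. The expected step is a 1.3-fold lower number from compound 1 to compound 4 (0.12 log units; within the scatter), a slight lean towards a lower number. For compound 4 the estimate is 60000 nM, with an expected range of 25000 nM to 120000 nM.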

Compound 4, half-maximal inhibitory concentration: 168000 nM
Beside the measured number, compound 4's estimate is 2.8-fold (0.45 log units) below it; measured number above the stated range.
By their numbers in this assay, from the lowest: compounds 2 and 3 (each within the scatter of the next); then compound 1; then compound 4.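

In this assay the substituent on a triple-bonded carbon does matter: phenethyl in place of 4-bromophenyl gives a 2.1-fold higher number from compound 1 to compound 4 (0.32 log units; beyond the scatter) and so moves the number beyond the scatter. Going by these compounds alone, the only earlier step at this place gave a 1.1-fold higher number from compound 2 to compound 3 (0.04 log units; within the scatter) and stayed within the scatter, so this place is not insensitive to every exchange, although the new step is modest. Nothing on hand accounts for the rise.

The exchange removes the bromine and also changes how the aromatic ring is attached to the triple bond, so the share of each in the step remains unresolved; a plain phenyl group at this place would separate the two. On these data alone, whether an amine or a carboxylic acid at the end of the chain would shift the number in either direction also remains open.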